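Removing the core phenyl of compound 1

The source may hold more compounds than are shown below. What is called first, only, known or untested is meant among the compounds shown, and "the series" means these compounds.

Compound 1 `CC(C)(C)c1ccc(NC(=O)N2CCC3(CC2)C(=O)N(c2ccccc2)[C@H]3c2ccccc2)cc1`: 9.4 nM
Compound 2 `CC(C)(c1ccccc1)c1ccc(NC(=O)N2CCC3(CC2)C(=O)N(c2ccccc2)[C@H]3c2ccccc2)cc1`: 226 nM

Within the data shown here, in a functional assay on HEK293 cells for antagonist activity at transient receptor potential cation channel subfamily V member 1 (Homo sapiens), read by FLIPR (a lower number here means a stronger inhibitor, a higher number a weaker inhibitor), compound 1 gives 9.4 nM, the lowest of the two numbers; the only measured step, a 24-fold higher number from compound 1 to compound 2 (1.38 log units; beyond the scatter), is large. Compound 3 `CC(C)(C)c1ccc(NC(=O)N2CCC3(CC2)CN(c2ccccc2)C3=O)cc1` differs from compound 1 by hydrogen in place of phenyl on a saturated ring carbon. Among the measured compounds shown here, no measured step touches this part of the shared core, so the measured step from compound 1 to compound 2 does not bear on it. For the measured compounds named here, the only guide is that compound 1 carries the lowest number; losing a ring from the core is expected to weaken inhibition, so a step of an 11-fold higher number from compound 1 to compound 3 (1.03 log units; beyond the scatter) is estimated. Compound 3 is therefore expected at 100 nM, between 20 nM and 600 nM.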

Compound 3, half-maximal inhibitory concentration: 80 nM
For compound 3 the middle estimate is 1.3-fold (0.10 log units) above the measured one; the measured number falls inside the stated range.
By their numbers in this assay, from the lowest: compound 1; then compound 3; then compound 2.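

Replacing the phenyl on this saturated ring carbon with hydrogen gives an 8.5-fold higher number from compound 1 to compound 3 (0.93 log units; beyond the scatter) in this assay, the first measured sign that this part of the shared core affects inhibition. The step is modest, and inhibition persists with hydrogen here, so the phenyl helps but is not required. Nothing available explains this difference. From the compounds shown here alone, what a benzyl group or an amine on this carbon would give remains open, as does whether removing the phenyl would have the same effect in compound 2.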